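A few compounds are considered here, and "the series" means these few. Any claim that something is new, unique, unknown or untested is made for them only; others in the source may bear on it.

Compound 1, `COc1cc(Cl)cc(-c2nn(-c3cccc(NC(=O)Nc4ccc(Cl)c(C(F)(F)F)c4)c3)cc2-c2ccncc2)c1`, gives 54% in a functional assay on HCT-15 cells (Homo sapiens) for inhibition, read by sulforhodamine B assay, with a stated time of 48 h, tested at 0.1 uM; a lower number here means a stronger effect, a higher number a weaker effect of the compound at the concentration tested.
Compound 2, `COc1cc(Cl)cc(-c2nn(-c3cccc(NC(=O)Nc4ccc(Cl)c(Cl)c4)c3)cc2-c2ccncc2)c1`, gives 53% in this assay.
Compound 3, `COc1cc(Cl)cc(-c2nn(-c3cccc(NC(=O)Nc4cccc(C(F)(F)F)c4)c3)cc2-c2ccncc2)c1`, gives 83% in this assay.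

Compound 3 stands highest of these three numbers, a number 29 percentage points higher from compound 1 to compound 3 (beyond the scatter) and a number 30 percentage points higher from compound 2 to compound 3 (beyond the scatter), while compounds 1 and 2 sit together, a number 1 percentage points lower from compound 1 to compound 2 (within the scatter). Compound 4, `COc1cc(Cl)cc(-c2nn(-c3cccc(NC(=O)c4cccc(C(F)(F)F)c4)c3)cc2-c2ccncc2)c1`, differs from compound 3 in one place: 3-(trifluoromethyl)phenyl in place of (3-(trifluoromethyl)phenyl)amino on a carbonyl carbon. For the measured compounds named here, none of the measured steps touches the carbonyl carbon or the amide-type nitrogen; all three vary only the terminal aromatic ring, so they give no direct guide to this change. Their sizes were modest at most, and the change here is of a different kind. Compound 4 is therefore expected to stay near compound 3, with a number 2 percentage points higher from compound 3 to compound 4 (within the scatter) as the estimated step, giving an expected value of 85%, ranging from 62% to 100%.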

Compound 4, a percentage reported as activity, at one concentration (the size of the read-out at that concentration, not a potency): 91%
The estimate for compound 4 lay 6 percentage points below the measured number; measured number inside the range.
By their numbers in this assay, from the lowest: compounds 2 and 1 (each within the scatter of the next); then compounds 3 and 4 (each within the scatter of the next).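

In this assay, for the compounds shown here, the first change at the carbonyl carbon, which removes the amino nitrogen and its hydrogen-bond donor, gives a number 8 percentage points higher from compound 3 to compound 4 (within the scatter), so here the amide cannot be told apart from the urea. The larger steps, a number 38 percentage points higher from compound 2 to compound 4 (beyond the scatter) and a number 37 percentage points higher from compound 1 to compound 4 (beyond the scatter), each combine this change with a different terminal ring and do not separate the two effects. Nothing available explains these numbers. Still open, on these data alone, is whether the 4-chloro-3-(trifluoromethyl)phenyl ring would keep its lower number on the amide, and what a sulfonamide would give at this position.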